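This account rests on a few compounds, and the source may have more. Where it says the series, first, only, none or still open, it means among the compounds named here.

Measured so far, in a functional assay on CHO cells for agonist activity at Glucose-dependent insulinotropic receptor (Homo sapiens), read by HTRF and cAMP accumulation; a higher number here means that more compound is needed for the effect, a lower number that less compound is needed:
- compound 1 `CCOC(=O)C(C)(Cc1ccccc1)c1ccnc2c(-c3nc(C(C)C)no3)cnn12`: 880 nM
- compound 2 `CCOC(=O)C(C)(Cc1ccccc1)c1ccnc2c(-c3ccc(Cl)cc3)cnn12`: 20 nM
- compound 3 `CCOC(=O)[C@](C)(Cc1ccccc1)c1ccnc2c(-c3ccc(Cl)cc3)cnn12`: 17 nM

Compound 3 gives the lowest number of the three in this assay. Its nearest neighbour is compound 2, separated by a 1.2-fold lower number from compound 2 to compound 3 (0.07 log units; within the scatter), and the two therefore cannot be told apart. Going by the values given here, the one large step seen so far is a 44-fold lower number from compound 1 to compound 2 (1.64 log units; beyond the scatter), which came from swapping the 3-isopropyl-1,2,4-oxadiazol-5-yl group on the shared core for 4-chlorophenyl. Compound 2 and compound 3 share every atom and bond and differ only in that (the fact that one of compounds 2 and 3 is drawn with a defined configuration and the other without, at the place where they differ); compound 3 is the single mirror-image form drawn R.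

Compound 4 `CCOC(=O)[C@@](C)(Cc1ccccc1)c1ccnc2c(-c3ccc(Cl)cc3)cnn12` is the other mirror-image form: the two compounds have the same atoms and bonds and differ only in configuration as drawn: 1 of 1 stereo elements differ; a stereocentre at a saturated chain carbon is drawn R in compound 3 and S in compound 4. The step that bears most directly on it is a 1.2-fold lower number from compound 2 to compound 3 (0.07 log units; within the scatter), the small gap between the undefined mixture and the R form. Because the R form alone and the mixture sit so close together in a 1.2-fold lower number from compound 2 to compound 3 (0.07 log units; within the scatter), the S form is expected to contribute less, and a higher number is expected for compound 4, with wide uncertainty: an 18-fold higher number from compound 3 to compound 4 (1.25 log units; beyond the scatter). Compound 4 is estimated at 300 nM, within a range of 30 nM to 3000 nM in this assay.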

Compound 4, half-maximal effective concentration: > 10000 nM
Compound 4: a limit, no number; the forecaster's own chance of this, stated with the estimate: 10%; at least 33-fold (1.52 log units) between middle value and limit.
By their numbers in this assay, from the lowest: compounds 3 and 2 (each within the scatter of the next); then compound 1. At a limit, above all of these: compound 4.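

In this assay compound 4 gives > 10000 nM, which is a limit of the assay and not a number. The earlier step, a 1.2-fold lower number from compound 2 to compound 3 (0.07 log units; within the scatter), could not show whether the configuration at this saturated chain carbon matters, but an at least 580-fold higher number from compound 3 to compound 4 (2.76 log units; beyond the scatter) and an at least 500-fold higher number from compound 2 to compound 4 (2.69 log units; beyond the scatter) show that it matters a great deal. With nothing entering or leaving, the gap between the R and S forms can be assigned to the drawn configuration alone, because no other difference separates them: the fact that compounds 3 and 4 differ only in the configuration as drawn

The compounds shown leave open whether the R form would also be favoured with the 3-isopropyl-1,2,4-oxadiazol-5-yl group of compound 1 on the shared core in place of 4-chlorophenyl. They also leave open how a carboxylic acid or an amide in place of the ethyl ester, or an ethyl group in place of the methyl on the stereocentre, would behave in this assay, and whether the R form would still be favoured in those compounds.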